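Pyridine ether and thioether variants of a TRPV1 antagonist series

The source may hold more compounds than are shown below. What is called first, only, known or untested is meant among the compounds shown, and "the series" means these compounds.

Compound 1 `CC(C(=O)NCc1ccc(C(C)(C)C)nc1N1CCCC1)c1ccc(NS(C)(=O)=O)c(F)c1`: 1.2 nM
Compound 2 `CC(C)Oc1nc(C(C)(C)C)ccc1CNC(=O)C(C)c1ccc(NS(C)(=O)=O)c(F)c1`: 2.3 nM

Both compounds were measured in an assay on cells for antagonist activity at transient receptor potential cation channel subfamily V member 1 (Homo sapiens), read by FLIPR and calcium flux, with a stated time of 6 min; a lower number here means a stronger inhibitor, a higher number a weaker inhibitor. Among the compounds with values here, compound 1 gives 1.2 nM and compound 2 gives 2.3 nM; the only measured step is a 1.9-fold higher number from compound 1 to compound 2 (0.28 log units; within the scatter). Compound 2 thus holds the higher of the two numbers, but the gap to compound 1 lies within the scatter, so no order between them can be read.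

Compound 3 `CCCCCSc1nc(C(C)(C)C)ccc1CNC(=O)C(C)c1ccc(NS(C)(=O)=O)c(F)c1` has not yet been measured. It differs from compound 2 by pentylsulfanyl in place of isopropoxy on an aromatic carbon. Within the data shown here, the single step on record at this position, a 1.9-fold higher number from compound 1 to compound 2 (0.28 log units; within the scatter), stayed within the scatter, so the data give no reason to expect a change beyond the scatter here either. Compound 3 is therefore estimated at 3 nM, with a range of 1 nM to 10 nM, which means an expected step of a 1.3-fold higher number from compound 2 to compound 3 (0.12 log units; within the scatter).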

Compound 3, inhibition constant: 3.1 nM
For compound 3 the middle estimate is 1.0-fold (0.01 log units) below the measured one, within the range that was stated.
By their numbers in this assay, from the lowest: compounds 1, 2 and 3 (each within the scatter of the next, the first and the last beyond it).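

In this assay, the carbon next to the ring nitrogen accepts a larger group with little effect on the number: pentylsulfanyl in place of isopropoxy, 6 heavy atoms for 4 and sulfur for oxygen, gives a 1.3-fold higher number from compound 2 to compound 3 (0.13 log units; within the scatter). Pentylsulfanyl in place of pyrrolidin-1-yl gives a 2.6-fold higher number from compound 1 to compound 3 (0.41 log units; beyond the scatter), the first step at this position beyond the scatter, though a modest one, while compound 2 stays within the scatter of both neighbours. No measurement beyond these numbers bears on why the steps have this size.

Going by these compounds, it remains open whether the sulfur or the chain length shapes the step from isopropoxy, which an isopropylsulfanyl or pentyloxy group on the same carbon would separate. On these data alone, how a primary amine or a carboxylic acid would read at this position also remains open.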